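The source may hold more compounds than are shown below. What is called first, only, known or untested is meant among the compounds shown, and "the series" means these compounds.

Compound 1, `O=C1CC(c2nc(-c3cccc(Cl)c3)no2)CN1c1ccc(Cl)cc1`, gives 140 nM in an in vitro functional assay on HEK293-A cells for positive allosteric modulation of metabotropic glutamate receptor 5 (Homo sapiens), read by FLIPR and calcium flux; a lower number here means that less compound is needed, a higher number that more compound is needed for the effect. Compound 2, `Cc1cccc(-c2noc(C3CC(=O)N(c4ccc(F)cc4)C3)n2)n1`, returns only > 10000 nM in this assay, which is a limit of the assay rather than a measured number. Compound 2 thus stands at the limit of > 10000 nM in this assay, at which 1 of the 2 values shown sits, the far end of the two values shown. Compound 3, `Cc1cccc(-c2noc(C3CC(=O)N(c4ccc(Cl)cc4)C3)n2)n1`, differs from compound 2 by chloro in place of fluoro on an aromatic carbon. Among the compounds with values here, no measured pair shows this change, so the shift expected in this assay is small, possibly none beyond the scatter, in either direction. Compound 3 is therefore estimated at 8000 nM, within 2000 nM to 30000 nM. The expected step is an at least 1.2-fold lower number from compound 2 to compound 3 (0.09 log units; that floor lies within the scatter).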

Compound 3, half-maximal effective concentration: > 10000 nM
Compound 3: only a limit was reported; the forecaster's own chance of this, stated with the estimate: 65%; middle value at least 1.2-fold (0.09 log units) away from the limit.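

In this assay compound 3 gives > 10000 nM, a limit of the assay, so the step for 4-fluorophenyl to 4-chlorophenyl cannot be read. With 4-chlorophenyl held constant, 6-methylpyridin-2-yl in place of 3-chlorophenyl gives an at least 71-fold higher number from compound 1 to compound 3 (1.85 log units; beyond the scatter), so 4-chlorophenyl alone does not preserve the response seen with 3-chlorophenyl. The limit is now shared: the limit of > 10000 nM in this assay, at which 2 of the 3 values shown sit.

Whether the methyl group or the ring nitrogen of 6-methylpyridin-2-yl accounts for the loss remains open. So does how a 3-methylphenyl or 3-methoxyphenyl group would read in that place.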